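Cytotoxicity notes: hydroxypentyl replacing furanylmethyl

The source may report more compounds than this note shows. Statements on the series, on what has been measured and on what is new or still open speak of the compounds shown alone.

Among the measured compounds shown here, compound 2 `CCOC(=O)C1(Cc2ccccc2)CN(c2ccccc2)Cc2nnn(Cc3ccco3)c21` carries the only number read in an ADME assay on HEL cells (Homo sapiens) for cytotoxicity, read by microscopy, with a stated time of 3 days; a higher number here means that more compound is tolerated, a lower number that less compound is tolerated; in this assay compound 2 gives 100000 nM. Compound 1 `CCOC(=O)C1(Cc2ccccc2)CN(c2ccccc2)Cc2nnn(Cc3ccccc3)c21` shows a limit of the assay, >= 20000 nM, in this assay. The step that the limit leaves unreadable from compound 1 to compound 2 is therefore unreadable, as noted by the limit of >= 20000 nM in this assay, at which 1 of the 2 values shown sits. Compound 3 `CCOC(=O)C1(Cc2ccccc2)CN(c2ccccc2)Cc2nnn(CCCCCO)c21` is not yet measured. Change: 4-hydroxybutyl in place of furan-2-yl on a saturated chain carbon bound to an aromatic nitrogen. For the measured compounds named here, no measured step bears readably on this change, so no direction is expected beyond the scatter, and a limit is possible. Compound 3 is expected to give 100000 nM in this assay, within 30000 nM to 100000 nM, a step of no change at the digits printed from compound 2 to compound 3 (within the scatter).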

Compound 3, minimum cytotoxic concentration: > 100000 nM
Compound 3: only a limit was reported; the forecaster's own chance of this, stated with the estimate: 40%; the middle value sits exactly at the limit.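

In this assay compound 3 gives > 100000 nM, which is a limit of the assay and not a number. Among the compounds shown here, on a saturated chain carbon bound to an aromatic nitrogen, the earlier compounds carried only aromatic rings; 4-hydroxybutyl, with no ring, in place of furan-2-yl gives a number no lower from compound 2 to compound 3 (the limit leaves the size open). The size of that step and the step involving compound 1 cannot be read: the limit of > 100000 nM in this assay, at which 1 of the 3 values shown sits.

Whether the ring-free chain itself or its hydroxyl group accounts for this reading stays open. A plain pentyl chain, a 5-aminopentyl group or a carboxylic acid at this place would begin to separate the two.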